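The source may report more compounds than this note shows. Statements on the series, on what has been measured and on what is new or still open speak of the compounds shown alone.

Compound 2 `CCCCCCCCCCCCCCCOC(=O)CCC(=O)N1CCN(CCCOc2cc3c(Nc4ccc(F)c(Cl)c4)ncnc3cc2OC)CC1` gives 92% in a functional assay on A549 cells (Homo sapiens) for cytotoxicity, read by MTT assay, with a stated time of 24 h, tested at 10 uM; a higher number here means a weaker effect of the compound at the concentration tested, a lower number a stronger effect. Compound 1 `CCCCOC(=O)CCC(=O)N1CCN(CCCOc2cc3c(Nc4ccc(F)c(Cl)c4)ncnc3cc2OC)CC1` gives 94.4% in this assay, and the two numbers sit within the scatter of each other, as the step of a number 2.4 percentage points lower from compound 1 to compound 2 (within the scatter) shows. Compound 3 `CCCCCCCCCCCCCCCCOC(=O)CCC(=O)N1CCN(CCCOc2cc3c(Nc4ccc(F)c(Cl)c4)ncnc3cc2OC)CC1` differs from compound 2 by methyl in place of hydrogen on a saturated chain carbon, ten or more bonds along the chain from an oxygen next to a carbonyl group. For the measured compounds named here, the only measured step, a number 2.4 percentage points lower from compound 1 to compound 2 (within the scatter), also lengthened this chain and stayed within the scatter, so the expected step of no change at the digits printed from compound 2 to compound 3 (within the scatter) is none beyond the scatter. Compound 3 is therefore estimated at 92% in this assay, with a range from 84% to 99%.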

Compound 3, a percentage reported as activity, at one concentration (the size of the read-out at that concentration, not a potency): 97.7%
Compound 3: the middle estimate sits 5.7 percentage points below what was measured, and the stated range covers the measured number.
By their numbers in this assay, from the lowest: compounds 2, 1 and 3 (each within the scatter of the next).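

In this assay the methyl in place of hydrogen on a saturated chain carbon gives a number 5.7 percentage points higher from compound 2 to compound 3 (within the scatter) and so does not separate the two compounds. The dodecyl change, made four bonds along the chain, gives a number 3.3 percentage points higher from compound 1 to compound 3 (within the scatter) and shows that even the largest chain difference here stays within the scatter. Nothing available explains why these chains give such similar numbers. Going by these compounds, whether an amine or a carboxylic acid at the chain end would give a step beyond the scatter stays open, as does the effect of a still longer chain.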